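A pyrrole ring in place of a methylphenyl on the carbonyl

This account rests on a few compounds, and the source may have more. Where it says the series, first, only, none or still open, it means among the compounds named here.

Of the compounds shown here, three sharing one core have been tested in a functional assay on CCRF-CEM cells (Homo sapiens) for cytotoxicity, with a stated time of 72 h; a higher number here means a weaker inhibitor, a lower number a stronger inhibitor. Compound 1 `C#CCOc1ccc(/C=C/C(=O)c2cccn2C)cc1OC` carries a 1-methyl-1H-pyrrol-2-yl group on the carbonyl carbon; in this assay compound 1 reaches only the limit > 50000 nM. Compound 2 `C#CCOc1ccc(/C=C/C(=O)c2cccc(C)c2)cc1OC` carries a 3-methylphenyl group instead, and in this assay compound 2 gives 8820 nM. Compound 3 `C#CCOc1ccc(/C=C/C(=O)c2ccc(C)cc2)cc1OC` carries a 4-methylphenyl group, and in this assay compound 3 again reaches only the limit > 50000 nM. Compound 3 thus stands at the limit of > 50000 nM in this assay, at which 2 of the 3 values shown sit, with no number of its own. Among the measured steps, an at least 5.6-fold lower number from compound 1 to compound 2 (0.75 log units; beyond the scatter) and an at least 5.6-fold higher number from compound 2 to compound 3 (0.75 log units; beyond the scatter) are both beyond the scatter, while a step that the two limits leave unreadable from compound 1 to compound 3 cannot be read from two limits. Compound 4 `C#CCOc1ccc(/C=C/C(=O)c2ccn(C)c2)cc1OC` differs from compound 3 by 1-methyl-1H-pyrrol-3-yl in place of 4-methylphenyl on a carbonyl carbon. Among the measured compounds shown here, the change exchanges the 4-methylphenyl for a 1-methyl-1H-pyrrol-3-yl; the only measured compound with a 1-methyl-pyrrolyl group, compound 1, sits at the limit, as does compound 3 itself, so no measured step points away from the limit. Compound 4 is therefore expected to stay at or near the limit, which means an expected step of a number no higher from compound 3 to compound 4 (the limit leaves the size open) in this assay. The estimate for compound 4 in this assay is 50000 nM, with a range from 15000 nM to 200000 nM.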

Compound 4, half-maximal inhibitory concentration: > 50000 nM
Compound 4: only a limit was reported (the forecaster's own chance of this, stated with the estimate: 70%); the middle value sits exactly at the limit.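

On the carbonyl carbon, a second pyrrole group now joins the series: with its 1-methyl-1H-pyrrol-3-yl group, compound 4 gives > 50000 nM in this assay, which is a limit and not a number. Both pyrrole groups shown therefore leave their compounds without a measured value, whether the ring is attached as the 1-methyl-1H-pyrrol-2-yl group of compound 1 or as the 1-methyl-1H-pyrrol-3-yl group of compound 4, and replacing the 3-methylphenyl group with the latter gives an at least 5.6-fold higher number from compound 2 to compound 4 (0.75 log units; beyond the scatter). The steps from compound 3 to compound 4 and from compound 1 to compound 4 cannot be read, so compound 2 remains the only one of the four with a measured number, and the rest share one limit: the limit of > 50000 nM in this assay, at which 3 of the 4 values shown sit.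

On these data alone, how compound 1, compound 3 and compound 4 rank against one another stays open, as none of them has a number of its own. Also open, as far as these compounds go, is whether a 3-methoxyphenyl or a 3-aminophenyl group on the carbonyl carbon would give a measured value like that of compound 2, or would fall to the same limit.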